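Title: From an isobutoxycarbonyl to a pivaloyl ester on the sugar chain

The source may hold more compounds than are shown below. What is called first, only, known or untested is meant among the compounds shown, and "the series" means these compounds.

Measured compounds:
Compound 1, `CCCSc1nc(N[C@@H]2C[C@H]2c2ccc(F)c(F)c2)c2nnn([C@@H]3C[C@H](OC(=O)CC)[C@@H](O)[C@H]3O)c2n1`: 44.5%
Compound 2, `CCCSc1nc(N[C@@H]2C[C@H]2c2ccc(F)c(F)c2)c2nnn([C@@H]3C[C@H](OC(=O)C(C)(C)C)[C@@H](O)[C@H]3O)c2n1`: "not active" (no number reported)
Compound 3, `CCCSc1nc(N[C@@H]2C[C@H]2c2ccc(F)c(F)c2)c2nnn([C@@H]3C[C@H](OCCOC(=O)OCC(C)C)[C@@H](O)[C@H]3O)c2n1`: "not determined" (no result reported)

Three compounds share one core and differ only in the ester placed on the hydroxyl of the cyclopentane ring. In a functional assay on the whole organism (strain Sprague-Dawley) for inhibition, with Rattus norvegicus as the target, with a stated time of 0.5 h, at a dose of 5 mg/kg by the oral route (on this read-out lower numbers stand for less inhibition and higher numbers for more inhibition at the one dose given (going by the name of the read-out)), compound 1 gives 44.5%, while compound 2 is reported as "not active" (no number reported) with no number attached. Compound 3 carries a two-carbon ether spacer before its carbonate and is recorded as "not determined" (no result reported), so it stands nowhere on the scale of this assay; no figure anchors it. Compound 4, `CCCSc1nc(N[C@@H]2C[C@H]2c2ccc(F)c(F)c2)c2nnn([C@@H]3C[C@H](OCCOC(=O)C(C)(C)C)[C@@H](O)[C@H]3O)c2n1`, keeps that spacer and changes the group on the carbonyl carbon: tert-butyl in place of isobutoxy on a carbonyl carbon. Among the measured compounds shown here, since no measured pair shows this step, its size is unknown; compound 1 gives 44.5% and compound 2 is reported as "not active" (no number reported), so esters of this kind may give a modest number in this assay or come back with only a reported verdict. Compound 4 is therefore expected to land at a modest level, around 25% in this assay, within a range from 0% to 55%, and the estimate carries a real chance that only the verdict "not active" is reported.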

Compound 4, a percentage reported as inhibition, in the whole organism at one dose (the size of the read-out at that dose, not a potency): 46.1%
Beside the measured number, compound 4's estimate is 21.1 percentage points below it, and the stated range covers the measured number.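

In this assay, replacing propanoyl with 2-(((tert-butyl)carbonyl)oxy)ethyl on an oxygen on a saturated carbon gives a number 1.6 percentage points higher from compound 1 to compound 4 (within the scatter), so this position accepts the larger group with no change beyond the scatter. A tert-butyl on a carbonyl carbon does not by itself go with a verdict in place of a number: compound 2 is recorded as "not active" (no number reported), whereas compound 4 gives 46.1%. The exchange of isobutoxy for tert-butyl cannot be read, as compound 3 has no result, and nothing given here accounts for these readings.

On these data alone, whether a longer chain in place of the ethyl spacer would still give a number in this assay remains open. So does the outcome for an amine or a carboxylic acid at the end of that spacer.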